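Series notes: methyl in place of fluoro on the aryl carbon

The source may hold more compounds than are shown below. What is called first, only, known or untested is meant among the compounds shown, and "the series" means these compounds.

Measured so far:
compound 1 `Clc1ccc(-c2csc(N/N=C/c3cccs3)n2)cc1`, 87.1%
compound 2 `Fc1ccc(-c2csc(N/N=C/c3cccs3)n2)cc1`, 92.4%

In a functional assay, read by spectrophotometry, with a stated time of 15 min, tested at 100 ug/mL (a higher number here means a stronger effect of the compound at the concentration tested, a lower number a weaker effect), compound 2 stands together with compound 1 at the top of the two numbers recorded; the difference, a number 5.3 percentage points higher from compound 1 to compound 2 (within the scatter), separates nothing. Compound 3 `Cc1ccc(-c2csc(N/N=C/c3cccs3)n2)cc1` is the next member to be measured. Compared with compound 2 the change is methyl in place of fluoro on an aromatic carbon.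

Among the compounds with values here, only one measured step bears on this change, the exchange of one small group for another at the same aromatic carbon, a number 5.3 percentage points higher from compound 1 to compound 2 (within the scatter). That step stayed inside the scatter. The change to compound 3 is of the same kind, with no ring, no donor, no acceptor and no charge entering or leaving. No step beyond the scatter is therefore expected in this assay in either direction. The expected step from compound 2 is a number 4.4 percentage points lower from compound 2 to compound 3 (within the scatter).

Compound 3 is expected to give about 88% in this assay, with a range from 76% to 96%.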

Compound 3, a percentage reported as inhibition, at one concentration (the size of the read-out at that concentration, not a potency): 91%
Compound 3: middle estimate off by 3 percentage points, on the low side, and the stated range covers the measured number.
By their numbers in this assay, from the lowest: compounds 1, 3 and 2 (each within the scatter of the next).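

Working notes: in this assay the aromatic carbon para to a large group now carries methyl as well as the two halogens, and the new steps read a number 1.4 percentage points lower from compound 2 to compound 3 (within the scatter) and a number 3.9 percentage points higher from compound 1 to compound 3 (within the scatter). The earlier pair compared only chloro with fluoro, whereas this result extends the flat reading to a group that is not a halogen, with compound 1, compound 2 and compound 3 not separable in this read-out. Within the data shown here, nothing measured so far bears on why these values sit together.

Still open, on these data alone, is whether this carbon accepts something of a different kind, such as an amine, a carboxylic acid or a longer chain, with a step beyond the scatter in this assay. The rest of the shared core is identical across all the compounds shown, and each read-out comes from a single concentration, so neither the contribution of the other parts of the core nor any difference in potency can be judged from these data.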